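The source may report more compounds than this note shows. Statements on the series, on what has been measured and on what is new or still open speak of the compounds shown alone.

Of the compounds shown here, three of a shared core have been tested so far in an assay on CHO cells for displacement of a labelled ligand from adenosine receptor A1 (Homo sapiens), read by scintillation counting, tested at 10 uM; a higher number here means more inhibition at the concentration tested (going by the name of the read-out), a lower number less inhibition. Compound 1, `CC(C)(C)Cc1c(/C=C/c2ccc(Cl)cc2)sc(N)c1C(=O)c1ccc(Cl)cc1`, gives 1%. Compound 2, `CC(C)(C)Cc1c(Br)sc(N)c1C(=O)c1cccc(Cl)c1`, gives 1%. Compound 3, `CC(C)(C)Cc1c(Br)sc(N)c1C(=O)c1cccc(C(F)(F)F)c1`, gives 1%, which leaves compound 3 level with compounds 1 and 2 at the digits shown; none of the three shows inhibition beyond the scatter in this assay.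

The next compound, compound 4, is `COc1ccc(-c2sc(N)c(C(=O)c3cccc(C(F)(F)F)c3)c2CC(C)(C)C)cc1`. Relative to compound 3 it carries a single change: 4-methoxyphenyl in place of bromo on an aromatic carbon.

Among the measured compounds shown here, only one measured step exists, and it concerns a different position: no change at the digits printed from compound 2 to compound 3 (within the scatter). For the measured compounds named here, no measured step touches the ring atom that bears the bromo in compound 3, so there is nothing that directly shows how swapping that bromo for a 4-methoxyphenyl behaves. Compound 1, which carries a large group on that same ring atom, sits just as low as compound 2 and compound 3, which hints that enlarging this position need not raise inhibition. The expectation for compound 4 is therefore a step of a number 2 percentage points higher from compound 3 to compound 4 (within the scatter), essentially none beyond the scatter. Compound 4 is estimated at 3%, with a range from -8% to 18%.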

Compound 4, a percentage reported as inhibition, at one concentration (the size of the read-out at that concentration, not a potency): 2%
Compound 4: the middle estimate sits 1 percentage points above what was measured, within the range that was stated.
By their numbers in this assay, from the lowest: compounds 1, 2, 3 and 4 (each within the scatter of the next).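

Swapping the lone bromo for 4-methoxyphenyl, a much larger group with a six-membered aromatic ring of its own, gives a number 1 percentage points higher from compound 3 to compound 4 (within the scatter) in this assay. Among the compounds shown here, this is the first measured step at this ring atom, the aromatic carbon next to the ring sulfur, and it shows that a direct change from a single atom to an aryl group can leave the read-out within the scatter. No evidence is available to explain this outcome.

On these data alone, whether an amine or a carboxylic acid on this ring atom, or a longer chain in place of the neopentyl group, would give clear inhibition remains open. As far as these compounds go, with all the compounds shown sitting this low in this assay, it is also open which part of the shared core, if any, can move this read-out.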